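This account rests on a few compounds, and the source may have more. Where it says the series, first, only, none or still open, it means among the compounds named here.

Compound 1 `CCn1c(=O)c2nc(-c3ccc(S(=O)(=O)N4CCOCC4)cc3)[nH]c2n(CC)c1=O` gives 13 nM in an assay for binding affinity to adenosine receptor A1 (Bos taurus); on this read-out higher numbers stand for weaker inhibition and lower numbers for stronger inhibition.
Compound 2 `Cn1c(=O)c2nc(-c3ccc(I)cc3)[nH]c2n(C)c1=O` gives 1.3 nM in this assay.
Compound 3 `Cn1c(=O)c2nc(-c3cccc(N)c3)[nH]c2n(C)c1=O` gives 10 nM in this assay.

Among these three, compound 2 stands at the lowest number, that is the strongest inhibition: compound 3 lies higher by a gap beyond the usual scatter, and compound 1 higher still, also beyond the scatter. Compound 4 `Cn1c(=O)c2nc(-c3ccc([N+](=O)[O-])cc3)[nH]c2n(C)c1=O` has not yet been measured. It differs from compound 2 in a single place: nitro in place of iodo on an aromatic carbon. For the measured compounds named here, no pair of measured compounds shows a change of this kind, so its size cannot be read from the data. A small move toward weaker inhibition is expected, of a size close to the scatter or only a little beyond it. Compound 4 is estimated at 3 nM, with a range from 0.8 nM to 12 nM. This estimate means an expected step of a 2.3-fold higher number from compound 2 to compound 4 (0.36 log units; beyond the scatter).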

Compound 4, half-maximal inhibitory concentration: 8 nM
The estimate for compound 4 lay 2.7-fold (0.43 log units) below the measured number, and the stated range covers the measured number.
By their numbers in this assay, from the lowest: compound 2; then compounds 4, 3 and 1 (each within the scatter of the next).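

For the compounds shown here, replacing iodo with nitro on this aromatic carbon, para to a large group, gives the first comparison here that differs in one place: in this assay there is a 6.2-fold higher number from compound 2 to compound 4 (0.79 log units; beyond the scatter), a modest step. The group at this position therefore affects the read-out, and of these two, iodo gives the stronger inhibition. Nothing available explains the size of this step. On these data alone, whether chloro or an amine at this position would stay nearer compound 2 or compound 4 remains open. So does whether the step would hold with ethyl groups in place of the methyl groups on the shared core.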